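A few compounds are considered here, and "the series" means these few. Any claim that something is new, unique, unknown or untested is made for them only; others in the source may bear on it.

Of the compounds shown here, three with a shared nitrofuran amide have been measured in an ADME assay on microsomes from liver (Homo sapiens) for metabolic stability; a lower number here means that the compound disappears faster, a higher number that the compound lasts longer. Compound 1, `COc1ccn2c(-c3ccc(NC(=O)c4ccc([N+](=O)[O-])o4)cc3C)cnc2c1`, gives 0.717 h. Compound 2, `COc1ccn2c(-c3ccc(NC(=O)c4ccc([N+](=O)[O-])o4)c(C)c3)cnc2c1`, gives 0.665 h. Compound 3, `Cc1cc(-c2cnc3ccccn23)ccc1NC(=O)c1ccc([N+](=O)[O-])o1`, gives 0.612 h. Compound 1 and compound 2 carry the same atoms joined differently; the difference between the two cores is not broken down here, and their two half-lives lie within the scatter of each other.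

Compound 2 and compound 3 differ in one place: hydrogen in place of methoxy on an aromatic carbon. That change made a step of a 1.1-fold lower number from compound 2 to compound 3 (0.04 log units; within the scatter), so the half-life was essentially unchanged.

Compound 4, `Cc1cc(NC(=O)c2ccc([N+](=O)[O-])o2)ccc1-c1cnc2ccccn12`, is not yet measured. Within the data shown here, it differs from compound 1 by hydrogen in place of methoxy on an aromatic carbon, the same change as the one from compound 2 to compound 3, made at the same place on the core.

Among the measured compounds shown here, with only that single precedent to go on, the expected step from compound 1 to compound 4 is a 1.1-fold lower number from compound 1 to compound 4 (0.04 log units; within the scatter), resting on the step of a 1.1-fold lower number from compound 2 to compound 3 (0.04 log units; within the scatter) seen between compound 2 and compound 3. Compound 4 is therefore estimated at 0.65 h, expected to fall between 0.4 h and 1.1 h.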

Compound 4, half-life: 0.687 h
Estimate against measurement, compound 4: 1.1-fold (0.02 log units) below; the range from low to high includes it.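

Putting hydrogen in place of methoxy on a second core gave a step of a 1.0-fold lower number from compound 1 to compound 4 (0.02 log units; within the scatter) in this assay, so here too the two half-lives cannot be told apart. Set beside the earlier case, the change behaved alike on both cores: the same change on two cores in this assay, a 1.1-fold lower number (0.04 log units; within the scatter) from compound 2 to compound 3 and a 1.0-fold lower number (0.02 log units; within the scatter) from compound 1 to compound 4, 1.0-fold (0.02 log units) apart, within the scatter of two such steps. This shows that, across these two cores, the change carried over as a step too small to distinguish from scatter, but it does not show that a change with a larger effect would carry over just as well, why the half-life stays so similar, or what would happen on any other core.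

The compounds shown compare only methoxy and hydrogen on that aromatic carbon, so it remains open whether another group there, such as an amine, a carboxylic acid or a longer chain, would move the half-life beyond the scatter. All four also keep the nitrofuran amide, which leaves open what a group such as a nitrile in place of the nitro group would do.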